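Nitro to amino on compound 3

The compounds below may be only part of what the source reports. "The series", "measured", "known", "first", "only" and "open" are said of these compounds alone.

In a functional assay on P388 cells (Mus musculus) for inhibition (on this read-out lower numbers stand for stronger inhibition and higher numbers for weaker inhibition), compound 1 `CC(=O)Oc1ccc(/C=C/c2ccc3ccccc3c2)cc1` gives > 5000 nM, which is a limit. Compound 2 `COc1ccc(/C=C/c2ccc3ccccc3c2)cc1[N+](=O)[O-]` gives > 5000 nM, also a limit. Compound 3 `COc1ccc(/C=C\c2ccc3ccccc3c2)cc1[N+](=O)[O-]` gives > 20000 nM, again a limit. Within the data shown here, no compound has yet returned a number, so compound 3 has a limit and no exact position.

Compound 4 `COc1ccc(/C=C\c2ccc3ccccc3c2)cc1N` is the next structure to be read: amino in place of nitro on an aromatic carbon. In words, this is amino in place of nitro on an aromatic carbon, ortho to a methoxy group.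

Among the measured compounds shown here, the only measured step that touches compound 3 is a step that the two limits leave unreadable from compound 2 to compound 3. It concerns the fact that compounds 2 and 3 differ only in the configuration as drawn and gives no size to carry forward. For the measured compounds named here, no measured pair makes the nitro to amino exchange, so the expected size has no direct precedent and stays loose.

With compound 3 at > 20000 nM, a limit, a change in this assay can be read only if it runs toward stronger inhibition, and that is the direction expected here. Another limit remains a real possibility. The estimated step is an at least 4.0-fold lower number from compound 3 to compound 4 (0.60 log units; beyond the scatter).

For compound 4 the expected value is 5000 nM, with an estimated range from 500 nM to 30000 nM.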

Compound 4, half-maximal inhibitory concentration: 1820 nM
Estimate against measurement, compound 4: 2.7-fold (0.44 log units) above; low and high end bracket the measured number.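

Nitro to amino at this position, on an aromatic carbon ortho to a methoxy group, is the first change in the series with a readable direction: in this assay it gives an at least 10-fold lower number from compound 3 to compound 4 (1.04 log units; beyond the scatter). Among these compounds, compound 4 gives 1820 nM, the first exact value, so the shared core with the double bond drawn Z can return a number in this read-out once amino stands at this place. The size of the step is only a lower bound because compound 3 rests on a limit: the limit of > 20000 nM in this assay, at which 1 of the 4 values shown sits.

Open, on these data alone, is whether amino itself is required at this place, or whether a hydroxyl or a dimethylamino group on the same aromatic carbon would give a comparable number in this assay. Equally open, as far as these compounds go, is what the same exchange does with the double bond drawn E, as in compound 2, which gives > 5000 nM, a limit.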